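This account rests on a few compounds, and the source may have more. Where it says the series, first, only, none or still open, it means among the compounds named here.

Three measured compounds share one core and differ only in the saturated chain that links an oxygen on the aromatic ring to a diethylamino group. Compound 1 `CCN(CC)CCCCOc1ccc(C(C)=O)c(O)c1` gives 22200 nM in an assay on isolated protein for inhibition of Amine oxidase [flavin-containing] B (Homo sapiens), read by fluorescence, with a stated time of 30 min; a higher number here means a weaker inhibitor, a lower number a stronger inhibitor. Compound 2 `CCN(CC)CCCOc1ccc(C(C)=O)c(O)c1` gives 16100 nM, and compound 3 `CCN(CC)CCCCCCOc1ccc(C(C)=O)c(O)c1` gives 22100 nM. Shortening the chain, a 1.4-fold lower number from compound 1 to compound 2 (0.14 log units; within the scatter), and lengthening it, a 1.0-fold lower number from compound 1 to compound 3 (0.00 log units; within the scatter), both leave the number where it was; compound 1 therefore sits with the other two, none of the three set apart from the rest.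

Compound 4 `CCN(CCCCOc1ccc(C(C)=O)c(O)c1)Cc1ccccc1` keeps the chain of compound 1 and changes the amine instead: phenyl in place of methyl on a saturated chain carbon bound to an amine nitrogen, which one bond further out reads as ethyl to benzyl. Among the measured compounds shown here, no measured step touches this part of the molecule; the two steps available concern only the chain length and were both within the scatter. There is thus no measured basis for a step in either direction, only the observation that changes elsewhere have so far moved nothing.

Compound 4 is accordingly expected to give about 15000 nM, with a wide range from 3000 nM to 60000 nM, which as a step means a 1.5-fold lower number from compound 1 to compound 4 (0.17 log units; within the scatter).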

Compound 4, half-maximal inhibitory concentration: 16600 nM
Estimate against measurement, compound 4: 1.1-fold (0.04 log units) below; the range from low to high includes it.
By their numbers in this assay, from the lowest: compounds 2, 4, 3 and 1 (each within the scatter of the next).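

Among the compounds shown here, compound 4 is the first compound here to change the amine rather than the chain, and phenyl in place of methyl on a saturated chain carbon bound to an amine nitrogen, which is the same as ethyl to benzyl, gives a 1.3-fold lower number from compound 1 to compound 4 (0.13 log units; within the scatter) in this assay. This place on the amine therefore takes one six-membered aromatic ring of carbon only while the number stays within the scatter, so a change at the amine end has so far had no more visible effect than the changes in chain length seen in compound 2 and compound 3. No measurement shown here offers an explanation for this lack of change.

The compounds shown leave open whether a chlorine or a methoxy group on the new phenyl ring, a longer chain between that ring and the nitrogen, or a dimethylamino group at the end of the chain would shift the number beyond the scatter. They also leave open whether benzyl would give the same result on the shorter chain of compound 2 or the longer chain of compound 3.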